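Removing the methoxy from compound 1: expected potency

The compounds below may be only part of what the source reports. "The series", "measured", "known", "first", "only" and "open" are said of these compounds alone.

Going by the values given here, compound 1 `COc1ccc(N(C(=O)CN2C=CN(c3ccccc3)C(=O)C(Cc3n[nH]c4ccccc34)C2=O)C(C)C)cc1` is the only member of the series with a single number in a functional assay on CHO cells for agonist activity at Melanocyte-stimulating hormone receptor (Homo sapiens), read by a luciferase reporter, with a stated time of 4 h (a higher number here means that more compound is needed for the effect, a lower number that less compound is needed), where compound 1 gives 29.5 nM; a further entry for compound 1 in this assay carries no single number. Compound 2 `CC(C)N(C(=O)CN1C=CN(c2ccccc2)C(=O)C(Cc2n[nH]c3ccccc23)C1=O)c1ccc(O)cc1` has three entries in this assay, 550 nM; 158 nM; 52.5 nM (3 entries), a wide spread (the several entries of compound 2 in this assay, 550 nM; 158 nM; 52.5 nM (3 entries)). Among the compounds with values here, no step between measured compounds is available, so the effect of changing the substituent on that aromatic ring has not been measured directly. Compound 3 `CC(C)N(C(=O)CN1C=CN(c2ccccc2)C(=O)C(Cc2n[nH]c3ccccc23)C1=O)c1ccccc1` differs from compound 1 by hydrogen in place of methoxy on an aromatic carbon. In this assay the step from compound 1 to compound 3 is expected to be small, a 1.9-fold higher number from compound 1 to compound 3 (0.27 log units; within the scatter), in the direction of more compound being needed, and possibly not beyond the scatter. Compound 3 is therefore estimated at 55 nM, with a range of 15 nM to 200 nM.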

Compound 3, half-maximal effective concentration: 708 nM
Beside the measured number, compound 3's estimate is 13-fold (1.11 log units) below it; the whole stated range lies below it.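

Replacing methoxy with hydrogen on the aromatic carbon para to a large group gives a 24-fold higher number from compound 1 to compound 3 (1.38 log units; beyond the scatter) in this assay, so this position is sensitive to the change and the phenyl of compound 3 does not stand in for the 4-methoxyphenyl of compound 1. Compound 3 at 708 nM also lies above all three entries of compound 2, which carries hydroxy at this place, so an oxygen-bearing group here goes with lower numbers in the compounds shown. That comparison stays loose, as repeat entries at this position differ widely: the several entries of compound 2 in this assay, 550 nM; 158 nM; 52.5 nM (3 entries).

The compounds shown leave open how an ethoxy, a chlorine or an amino group at this place would compare with methoxy. Also open, going by these compounds, is whether the step recurs when the isopropyl gives way to a longer chain.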